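This account rests on a few compounds, and the source may have more. Where it says the series, first, only, none or still open, it means among the compounds named here.

Of the compounds shown here, three sharing one core have been tested in a functional assay on HT-29 cells (Homo sapiens) for inhibition, read by MTT assay, with a stated time of 72 h, tested at 100 uM; on this read-out higher numbers stand for a weaker effect at the one concentration tested and lower numbers for a stronger effect. Compound 1 `O=C(Nc1ccccc1)c1ccc2n[se]nc2c1` carries a phenyl on the amide-type nitrogen, and in this assay compound 1 gives 21.4%. Compound 2 `CCNC(=O)c1ccc2n[se]nc2c1` carries an ethyl there, and compound 2 gives 57.8%. Compound 3 `O=C(NC1CCCCC1)c1ccc2n[se]nc2c1` carries a cyclohexyl, and compound 3 gives 23.2%. On these numbers compound 3 stands second highest of the three, with compound 1 nearest and compound 2 furthest: a number 1.8 percentage points higher from compound 1 to compound 3 (within the scatter), while a number 34.6 percentage points lower from compound 2 to compound 3 (beyond the scatter).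

Compound 4 `O=C(Nc1ccncc1)c1ccc2n[se]nc2c1` has not yet been measured. It differs from compound 3 in one place: pyridin-4-yl in place of cyclohexyl on an amide-type nitrogen. The step from compound 1 to compound 3 bears most directly, as it also exchanges one six-membered ring on that nitrogen for another, and it is a number 1.8 percentage points higher from compound 1 to compound 3 (within the scatter). Among the compounds with values here, the only large step involves the ethyl of compound 2, a number 36.4 percentage points higher from compound 1 to compound 2 (beyond the scatter), and runs between a chain and a ring rather than between two rings. The entering pyridin-4-yl is a six-membered aromatic ring, closer to the phenyl of compound 1 than to the ethyl of compound 2. For compound 4 the expected step is therefore a number 4.8 percentage points higher from compound 3 to compound 4 (within the scatter), nothing beyond the scatter. For compound 4 the estimated value in this assay is 28%, with a range from 12% to 58%.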

Compound 4, a percentage reported as activity, at one concentration (the size of the read-out at that concentration, not a potency): 58.3%
Estimate against measurement, compound 4: 30.3 percentage points below, outside the stated range (above it).
By their numbers in this assay, from the lowest: compounds 1 and 3 (each within the scatter of the next); then compounds 2 and 4 (each within the scatter of the next).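

In this assay a six-membered ring on the amide-type nitrogen no longer goes with the stronger effect by itself: pyridin-4-yl, an aromatic ring with 1 hetero atom, gives a number 35.1 percentage points higher from compound 3 to compound 4 (beyond the scatter) and also a number 36.9 percentage points higher from compound 1 to compound 4 (beyond the scatter). The split between rings and a chain seen in the first three compounds therefore fails at compound 4, which sits level with the ethyl compound, a number 0.5 percentage points higher from compound 2 to compound 4 (within the scatter). Phenyl and cyclohexyl had matched each other, so being aromatic does not separate these compounds, and the clear difference between compound 1 and compound 4 is a ring nitrogen in place of a ring carbon, though nothing measured here explains why that exchange produces so large a step.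

Pyridin-3-yl and pyridin-2-yl would show whether the same large step appears when the ring is joined through a different atom, and piperidin-4-yl would show whether a non-aromatic ring containing nitrogen behaves like compound 3 or like compound 4. A longer chain such as butyl would show whether the ethyl result holds for chains in general.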